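Notes on a quinoline carboxamide series: methoxy on the aryl

The compounds below may be only part of what the source reports. "The series", "measured", "known", "first", "only" and "open" are said of these compounds alone.

Within the data shown here, compound 3 `COc1cc2c(Oc3ccc(NC(=O)c4cc(-c5ccccc5)nc5ccc(F)cc45)cc3F)ccnc2cc1OCCCN1CCCC1` gives 90 nM in a functional assay on NCI-H460 cells (Homo sapiens) for cytotoxicity, read by MTT assay, with a stated time of 72 h (on this read-out lower numbers stand for stronger inhibition and higher numbers for weaker inhibition), the second highest of the three numbers measured so far. Among the measured compounds shown here, its nearest neighbour is compound 2 `COc1cc2c(Oc3ccc(NC(=O)c4cc(-c5ccccc5)nc5ccc(F)cc45)cc3F)ccnc2cc1OCCCN1CCCCC1`, which in this assay gives 32 nM; the only single-point step measured, a 2.8-fold higher number from compound 2 to compound 3 (0.45 log units; beyond the scatter), separates these two. Furthest away stands compound 1 `COc1cc2c(Oc3ccc(NC(=O)c4cc(-c5ccc(C)cc5)nc5ccccc45)cc3F)ccnc2cc1OCCCN1CCC(C)CC1`, which in this assay gives 880 nM; compound 1 differs from compound 3 in several places at once, so its value alone cannot be tied to any one change.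

Compound 4 `COc1ccc(-c2cc(C(=O)Nc3ccc(Oc4ccnc5cc(OCCCN6CCCC6)c(OC)cc45)c(F)c3)c3cc(F)ccc3n2)cc1` differs from compound 3 by methoxy in place of hydrogen on an aromatic carbon. For the measured compounds named here, no measured step touches the aryl on the shared core, and the one measured step, a 2.8-fold higher number from compound 2 to compound 3 (0.45 log units; beyond the scatter), concerns the amine at the end of the chain, so it offers no direct guide to the present change. With nothing bearing on it, the expectation in this assay is for no step beyond the scatter, direction open, and a wider range than usual is kept. Compound 4 is therefore estimated at 110 nM, within 35 nM to 350 nM. The step this estimate implies, a 1.2-fold higher number from compound 3 to compound 4 (0.09 log units; within the scatter), is expected to be small.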

Compound 4, half-maximal inhibitory concentration: 250 nM
Beside the measured number, compound 4's estimate is 2.3-fold (0.36 log units) below it; low and high end bracket the measured number.
By their numbers in this assay, from the lowest: compound 2; then compound 3; then compound 4; then compound 1.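

In this assay, among these compounds, the phenyl to 4-methoxyphenyl change reads as a 2.8-fold higher number from compound 3 to compound 4 (0.44 log units; beyond the scatter) and is the first measured step at this aryl position. The aryl on the shared core therefore joins the amine at the end of the chain as a place where a single change moves the number beyond the scatter, and here methoxy on the aromatic carbon, para to a large group, goes with weaker inhibition on this one background. No measured evidence accounts for this step.

Going by these compounds, whether the step belongs to methoxy in particular or to any group in this place stays open: a chlorine, a hydroxyl or a dimethylamino group on the same aromatic carbon would separate those readings, and compound 1, which carries a methyl on this aryl, differs from compound 3 in several places and cannot settle it. Also open is whether the same step would appear with the piperidin-1-yl chain end of compound 2, since the methoxy is shown only with the pyrrolidin-1-yl chain end.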